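The compounds below may be only part of what the source reports. "The series", "measured", "known", "first", "only" and "open" are said of these compounds alone.

Within the data shown here, in an ADME assay on microsomes from liver (Homo sapiens) for metabolic stability (a higher number here means that the compound lasts longer, a lower number that the compound disappears faster), compound 1 `Cc1cccc(NC(=O)c2nn(C)c(-c3ccccc3)c2C)n1` gives 1.1 h and compound 2 `Cc1cccc(NC(=O)c2nn(C)c(-c3ccc(F)cc3F)c2C)n1` gives 1.12 h, so compound 2 stands level with the only other number available. Compound 3 `Cc1cccc(NC(=O)c2nn(C)c(-c3cc(F)cc(F)c3)c2C)n1` keeps the shared core and differs from compound 2 in one place: 3,5-difluorophenyl in place of 2,4-difluorophenyl on an aromatic carbon. Among the measured compounds shown here, one measured step bears on this change, the swap of phenyl for 2,4-difluorophenyl on the same aromatic carbon, a 1.0-fold higher number from compound 1 to compound 2 (0.01 log units; within the scatter), which lies within the scatter. For the measured compounds named here, no compound carrying 3,5-difluorophenyl has been measured, so this evidence is only indirect. No step beyond the scatter is expected in this assay, and the estimated step is a 1.0-fold lower number from compound 2 to compound 3 (0.01 log units; within the scatter). For compound 3 the estimated half-life is 1.1 h, with an expected range of 0.6 h to 2 h.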

Compound 3, half-life: 0.533 h
Estimate against measurement, compound 3: 2.1-fold (0.31 log units) above; measured number outside the range, below it.
By their numbers in this assay, from the lowest: compound 3; then compounds 1 and 2 (each within the scatter of the next).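

In this assay, the arrangement of the two fluorines on the phenyl group matters at this position: 3,5-difluorophenyl in place of 2,4-difluorophenyl gives a 2.1-fold lower number from compound 2 to compound 3 (0.32 log units; beyond the scatter) even though the two groups have the same atoms. Against the unsubstituted phenyl group, the same change gives a 2.1-fold lower number from compound 1 to compound 3 (0.31 log units; beyond the scatter) and so a modest step, which the 2,4-difluorophenyl group did not produce, so among these compounds the presence of two fluorines alone does not set the half-life. The data at hand give no explanation for this difference.

On these data alone, whether a single fluorine on the phenyl group would produce a step remains open. As far as these compounds go, it is also open how a methoxy group or a nitrile on that phenyl group, or a cyclohexyl group in its place, would compare with these three compounds.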